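Ester to amide on the saturated ring of the shared core

The compounds below may be only part of what the source reports. "The series", "measured", "known", "first", "only" and "open" are said of these compounds alone.

Among the measured compounds shown here, compound 2 `COc1ccc(C(=O)OC2CCC(CN3CCN(c4cc(=O)c5cc(C(F)(F)F)cc([N+](=O)[O-])c5s4)CC3)CC2)cc1` gives the only plain number in an ADME assay on cells (Hepatocyte, Mus musculus) for metabolic stability (a higher number here means that the compound lasts longer, a lower number that the compound disappears faster), 0.295 h. Compound 1 `O=C(OC1CCC(CN2CCN(c3cc(=O)c4cc(C(F)(F)F)cc([N+](=O)[O-])c4s3)CC2)CC1)c1ccco1` reaches only a limit, < 0.075 h, so its value is a limit of this assay and not a number (the limit of < 0.075 h in this assay, at which 1 of the 2 values shown sits). For the measured compounds named here, the one measured step, an at least 3.9-fold higher number from compound 1 to compound 2 (0.59 log units; beyond the scatter), changes the group on the carbonyl carbon and is the nearest guide. Compound 3 `O=C(NC1CCC(CN2CCN(c3cc(=O)c4cc(C(F)(F)F)cc([N+](=O)[O-])c4s3)CC2)CC1)c1ccccc1` differs from compound 2 by benzamido in place of ((4-methoxyphenyl)carbonyl)oxy on a saturated ring carbon. The step from an ester to an amide is not covered by any measured pair, so the estimate is loose; a modest rise is expected, a 2.0-fold higher number from compound 2 to compound 3 (0.31 log units; beyond the scatter). Compound 3 is expected to give 0.6 h, between 0.2 h and 2 h.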

Compound 3, half-life: > 1.55 h
Compound 3 gave a limit, no number; the forecaster's own chance of this, stated with the estimate: 10%; middle value at least 2.5-fold (0.41 log units) away from the limit.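

Compound 3 sits at a limit of this assay, not at a number: the limit of > 1.55 h in this assay, at which 1 of the 3 values shown sits. Benzamido in place of the ester on the saturated ring carbon gives an at least 5.2-fold higher number from compound 2 to compound 3 (0.72 log units; beyond the scatter), and against the furan-2-yl ester it gives an at least 20-fold higher number from compound 1 to compound 3 (1.31 log units; beyond the scatter). From the compounds shown here alone, the number here therefore moves with the link on this ring carbon as well as with the group on the carbonyl carbon, though the full size of both steps stays unknown.

The compounds shown leave open whether the amide nitrogen or the absent methoxy accounts for the rise, which a 4-methoxybenzamido group would separate. Going by these compounds, how a furan-2-carboxamido group or a plain amine would fare on this ring carbon also remains open.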